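Swapping the hydroxyethyl amide tail for a carboxyethyl one

The compounds below may be only part of what the source reports. "The series", "measured", "known", "first", "only" and "open" are said of these compounds alone.

Compound 1, `NCCNC(=O)Cn1nc(N)c2c(C(F)(F)F)cc(-c3ccccc3)nc21`: 50200 nM
Compound 2, `Nc1nn(CC(=O)NCCO)c2nc(-c3ccccc3)cc(C(F)(F)F)c12`: 128000 nM
Compound 3, `CN1CCN(C(=O)Cn2nc(N)c3c(C(F)(F)F)cc(-c4ccccc4)nc32)CC1`: 18400 nM

All three compounds share one core and differ only in the group attached to the carbonyl carbon of the side chain, and all were tested in a functional assay on A549 cells (Homo sapiens) for cytotoxicity, read by MTT assay, with a stated time of 24 h; a lower number here means a stronger inhibitor, a higher number a weaker inhibitor. Compound 2 stands at the top of the three numbers, meaning it is the weakest of the set: the step of a 2.5-fold higher number from compound 1 to compound 2 (0.41 log units; beyond the scatter) raised the number, and the step of a 7.0-fold lower number from compound 2 to compound 3 (0.84 log units; beyond the scatter) lowered it again. Both steps are modest in size but beyond the usual scatter.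

Compound 4, `CC(NC(=O)Cn1nc(N)c2c(C(F)(F)F)cc(-c3ccccc3)nc21)C(=O)O`, has not been measured yet. Compared with compound 2, (1-carboxyethyl in place of 2-hydroxyethyl on an amide-type nitrogen). Among the compounds with values here, no measured step introduces a carboxyl group, so the only guidance is that changes at this amide nitrogen have so far moved the number by modest amounts in either direction. With compound 2 already at the weak end, a step of similar size, or none beyond the scatter, seems the most likely outcome. For compound 4 in this assay the expected value is therefore 150000 nM, estimated to lie between 50000 nM and 450000 nM. The expected step for compound 4 is a 1.2-fold higher number from compound 2 to compound 4 (0.07 log units; within the scatter).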

Compound 4, half-maximal inhibitory concentration: 25600 nM
Compound 4: middle estimate off by 5.9-fold (0.77 log units), on the high side; the whole stated range lies above it.
By their numbers in this assay, from the lowest: compounds 3, 4 and 1 (each within the scatter of the next, the first and the last beyond it); then compound 2.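

In this assay, changing 2-hydroxyethyl to 1-carboxyethyl on the amide-type nitrogen gives a step beyond the scatter (a 5.0-fold lower number from compound 2 to compound 4 (0.70 log units; beyond the scatter)), so this position can respond to a change in the tail even when the amide and the shared core stay the same. The new tail also cannot be told apart from the other two, whether set against the 4-methylpiperazin-1-yl amide (a 1.4-fold higher number from compound 3 to compound 4 (0.14 log units; within the scatter)) or the 2-aminoethyl tail (a 2.0-fold lower number from compound 1 to compound 4 (0.29 log units; within the scatter)), as both steps lie within the scatter, which leaves compound 2 as the weakest of the four, with its steps to all three others beyond the scatter. Nothing measured here accounts for why the carboxyl-bearing tail and the hydroxy-bearing tail part ways.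

This single change alters two things at once, replacing the hydroxy group with a carboxylic acid and moving from a straight chain to a branched one, so the compounds shown cannot say which of the two matters. An unbranched carboxylic acid chain and a branched chain ending in a hydroxy group would separate these two parts.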